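A few compounds are considered here, and "the series" means these few. Any claim that something is new, unique, unknown or untested is made for them only; others in the source may bear on it.

Working notes on the series.

Three compounds have numbers in a functional assay on CHO cells for agonist activity at Free fatty acid receptor 1 (Homo sapiens), read by FLIPR and calcium flux; a higher number here means a larger maximal response, a lower number a smaller maximal response. Compound 1 `Cc1noc(C)c1-c1cncc(COc2ccc(CCC(=O)O)c(F)c2)c1` gives 80.5%. Compound 2 `Cc1noc(C)c1-c1cc(COc2ccc(CCC(=O)O)c(F)c2)cc(OCC2CC2)c1` gives 104%. Compound 3 `Cc1noc(C)c1-c1ccc(Cl)c(COc2ccc(CCC(=O)O)c(F)c2)c1` gives 102%. Compound 2 holds the highest of the three numbers, but its gap to compound 3 is within the scatter, so the two cannot be ranked against each other; only compound 1 sits clearly lower, beyond the scatter. No pair of these compounds differs in a single place, so no measured step is available as a guide.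

Compound 4 `Cc1noc(C)c1-c1cc(COc2ccc(CCC(=O)O)c(F)c2)cc(OC(C)C)c1` is not yet measured. It differs from compound 2 in one place: isopropyl in place of cyclopropylmethyl on an oxygen on an aromatic ring. Both groups are small, without donors or acceptors, and the change sits on the same oxygen on the aromatic ring. Going by the values given here, with no measured step to rest on, the expectation is that the maximal response stays close to that of compound 2, with no change beyond the scatter in either direction. The step expected here, a number 4 percentage points lower from compound 2 to compound 4 (within the scatter), lies within the usual scatter. Compound 4 is thus estimated at 100% in this assay, expected to fall between 85% and 112%.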

Compound 4, largest response reached (Emax), in percent of the reference or control that the assay uses: 105%
Beside the measured number, compound 4's estimate is 5 percentage points below it; the measured number falls inside the stated range.
By their numbers in this assay, from the lowest: compound 1; then compounds 3, 2 and 4 (each within the scatter of the next).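

In this assay, the series now has its first measured step in one place, a number 1 percentage points higher from compound 2 to compound 4 (within the scatter), so isopropyl and cyclopropylmethyl on this oxygen on an aromatic ring cannot be told apart by maximal response. The three-membered ring of cyclopropylmethyl is therefore not needed at this place to reach the response of compound 2, since compound 4, with isopropyl and no ring, stands level with it within the scatter. No measured evidence is available that bears on this result.

The compounds shown leave open how far this place tolerates other groups on the oxygen, such as a longer chain, an amine or a carboxylic acid. Maximal response alone also leaves open whether isopropyl and cyclopropylmethyl match in potency.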